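Methylsulfanyl for methoxy in compound 3

The source may report more compounds than this note shows. Statements on the series, on what has been measured and on what is new or still open speak of the compounds shown alone.

In an ADME assay on the whole organism (Mus musculus, strain CD-1) for pharmacokinetics, at a dose of 10 mg/kg by the oral route (on this read-out higher numbers stand for higher oral bioavailability and lower numbers for lower oral bioavailability), compound 3 `COc1cc([C@](O)(CCN(C)C)[C@@H](c2cc3cc(C#N)ccc3nc2OC)c2cccc(OC)c2F)cc(SC)n1` gives 28%. Compound 2 `COc1cc([C@](O)(CCN(C)C)[C@@H](c2cc3cc(Br)ccc3nc2OC)c2cccc(OC)c2F)cc(SC)n1` gives 31%, within the scatter of that number, and compound 1 `COc1cc([C@](O)(CCN(C)C)[C@@H](c2cc3cc(Br)ccc3nc2OC)c2ccnc(OC)c2OC)cc(OC2CCC2)n1` gives 56%, well clear of both. Compound 4 `COc1cccc([C@H](c2cc3cc(C#N)ccc3nc2OC)[C@@](O)(CCN(C)C)c2cc(SC)nc(SC)c2)c1F` departs from compound 3 in one place: methylsulfanyl in place of methoxy on an aromatic carbon. Methylsulfanyl thus takes the place of methoxy on an aromatic carbon, next to the ring nitrogen and meta to a methylsulfanyl group. Among the compounds with values here, only one measured step changes a single place, and it concerns a different part of the molecule: a number 3 percentage points lower from compound 2 to compound 3 (within the scatter), with cyano in place of bromo on an aromatic carbon. That step stays within the scatter. Within the data shown here, no measured pair shows this exchange of methoxy for methylsulfanyl, so the evidence for the coming step is thin. In this assay the expected step is a number 2 percentage points lower from compound 3 to compound 4 (within the scatter), which would be no shift beyond the scatter. Compound 4 is expected at 26%, with an estimated range from 12% to 42%.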

Compound 4, oral bioavailability: 28%
Compound 4: the middle estimate sits 2 percentage points below what was measured, within the range that was stated.
By their numbers in this assay, from the lowest: compounds 3, 4 and 2 (each within the scatter of the next); then compound 1.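

With methylsulfanyl in place of methoxy on this aromatic carbon, next to the ring nitrogen, this assay gives no change at the digits printed from compound 3 to compound 4 (within the scatter), so this exchange moves the oral bioavailability of the cyano compounds by no more than the scatter. Within the data shown here, the earlier single-place step concerned cyano and bromo in a different part of the molecule, so this is the first reading at this position, and it covers only this one exchange. Nothing measured here bears on why the number stays put.

From the compounds shown here alone, whether this position accepts a group of another kind, such as an amine, a carboxylic acid or a longer alkoxy chain, remains open. Also open, going by these compounds, is whether the same exchange would give a similar step with bromo in place of cyano, as in compound 2.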